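Methyl additions and cell toxicity in a pyrimidinone series

The source may report more compounds than this note shows. Statements on the series, on what has been measured and on what is new or still open speak of the compounds shown alone.

The measured compounds:
- Compound 1 `O=c1cc(Cc2c(F)cccc2F)nc(N2CCCCC2)[nH]1`: in an ADME assay on MT4 cells (Homo sapiens) for cytotoxicity, read by MTT assay, with a stated time of 4 days (on this read-out higher numbers stand for lower toxicity in this test and lower numbers for higher toxicity in this test), compound 1 gives > 82000 nM, which is a limit of the assay and not a number.
- Compound 2 `CC1CCCN(c2nc(Cc3c(F)cccc3F)cc(=O)[nH]2)C1`: in this assay compound 2 gives > 78000 nM, again a limit of the assay.
- Compound 3 `Cc1c(Cc2c(F)cccc2F)nc(N2CCCCC2)[nH]c1=O`: in this assay compound 3 gives > 78000 nM, also a limit of the assay.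

All three compounds share one core. Compound 2 differs from compound 1 by methyl in place of hydrogen on a saturated ring carbon, and the step this made, a step that the two limits leave unreadable from compound 1 to compound 2, cannot be sized because both values are limits. Compound 3 differs from compound 1 by methyl in place of hydrogen on an aromatic carbon; here too a step that the two limits leave unreadable from compound 1 to compound 3 is left unreadable by the two limits.

Compound 4 `Cc1c(Cc2c(F)cccc2F)nc(N2CCCCC2C)[nH]c1=O` is not yet measured. It differs from compound 3 by methyl in place of hydrogen on a saturated ring carbon. Among the measured compounds shown here, this is the same kind of change as the one from compound 1 to compound 2, not the same change: in compound 2 the methyl sits two ring bonds from the ring nitrogen and two ring bonds from the ring atom that bears a large group, whereas in compound 4 it sits next to the ring nitrogen and next to the ring atom that bears a large group.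

The expectation for compound 4 rests on the limit of > 78000 nM in this assay, at which 2 of the 3 values shown sit, and (the limit of > 82000 nM in this assay, at which 1 of the 3 values shown sits), which show no measurable toxicity anywhere among the three compounds. From compound 3, the step that the limit leaves unreadable from compound 3 to compound 4 is expected to stay small. Compound 4 is therefore estimated at 80000 nM, within 35000 nM to 200000 nM, most likely reported again only as a limit.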

Compound 4, half-maximal cytotoxic concentration: 75000 nM
Compound 4: middle estimate off by 1.1-fold (0.03 log units), on the high side; the measured number falls inside the stated range.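

In this assay, the change from piperidin-1-yl to 2-methylpiperidin-1-yl on the core of compound 3 makes an at least 1.0-fold lower number from compound 3 to compound 4 (0.01 log units; that floor lies within the scatter), and this floor is all that the data fix. Compound 3 gives > 78000 nM, which is a limit of the assay and not a number, so the true step may be larger than this floor. Whether the change carries from one core to another cannot be judged: the steps that start from compound 1 cannot be read, and the methyl of compound 2 sits at a different ring carbon from the methyl of compound 4, which makes them the same kind of change but not the same change.

Open, going by these compounds, is whether a bigger or different group at this place, such as an ethyl, a phenyl, an amine or a carboxylic acid, would bring a readable number in this assay. Also open is how 2-methylpiperidin-1-yl would read on the core of compound 1, the direct partner for this step, and the values shown give little to go on, since a limit recurs among them: the limit of > 78000 nM in this assay, at which 2 of the 4 values shown sit.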